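Amide nitrogen swap on the dichlorophenyl analogue

The compounds below may be only part of what the source reports. "The series", "measured", "known", "first", "only" and "open" are said of these compounds alone.

Measured compounds:
compound 1 `C=CC1=C(C(=O)Nc2ccccc2OC)C(c2ccc(F)cc2)OC1`: 52800 nM
compound 2 `C=CC1=C(C(=O)NCC(C)C)C(c2ccc(Cl)c(Cl)c2)OC1`: > 100000 nM

In a functional assay on QGY7701 cells (Homo sapiens) for cytotoxicity, read by MTT assay, with a stated time of 24 h (a higher number here means a weaker inhibitor, a lower number a stronger inhibitor), compound 1 gives 52800 nM. For compound 2 this assay reports only a limit, > 100000 nM, and no number. On the values shown, compound 2 thus sits at the weak end, at the limit of > 100000 nM in this assay, at which 1 of the 2 values shown sits.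

Compound 3 `C=CC1=C(C(=O)Nc2ccccc2OC)C(c2ccc(Cl)c(Cl)c2)OC1` is not yet measured in this assay. It differs from compound 2 in one place: 2-methoxyphenyl in place of isobutyl on an amide-type nitrogen. For the measured compounds named here, no measured pair isolates this change. Compound 1 carries the same 2-methoxyphenyl amide as compound 3 but a different aryl group on the shared core, so its value gives an orientation only. A move toward stronger inhibition seems likely, since compound 1 with the 2-methoxyphenyl amide does return a number, while compound 2 does not; the step is expected as an at least 1.6-fold lower number from compound 2 to compound 3 (0.22 log units; that floor lies within the scatter), its size uncertain because compound 2 is only a limit (the limit of > 100000 nM in this assay, at which 1 of the 2 values shown sits). Compound 3 is estimated at 60000 nM, with a range from 25000 nM to 150000 nM, and a real chance that this assay again reports only a limit.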

Compound 3, half-maximal inhibitory concentration: > 100000 nM
Compound 3: no number, only a limit (the forecaster's own chance of this, stated with the estimate: 35%); middle value at least 1.6-fold (0.22 log units) away from the limit.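

Compound 3 is also a limit, > 100000 nM, in this assay. With 3,4-dichlorophenyl on the shared core, neither isobutyl nor 2-methoxyphenyl on the amide-type nitrogen gives a number, and the step between compound 2 and compound 3 cannot be read: the limit of > 100000 nM in this assay, at which 2 of the 3 values shown sit. With the 2-methoxyphenyl amide held constant, 3,4-dichlorophenyl in place of 4-fluorophenyl on a saturated ring carbon gives an at least 1.8-fold higher number from compound 1 to compound 3 (0.27 log units; that floor lies within the scatter), so this one-place comparison does not establish a real loss, although it does show that the 2-methoxyphenyl amide alone does not ensure a number in this series.

The compounds shown leave open whether any group on the amide-type nitrogen can bring the 3,4-dichlorophenyl analogues to a number, for example a 2-(dimethylamino)ethyl chain or a phenyl ring carrying a carboxylic acid. They also leave open how isobutyl on the amide-type nitrogen reads with 4-fluorophenyl on the saturated ring carbon, which would separate the contribution of the amide group from that of the aryl group.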